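The compounds below may be only part of what the source reports. "The series", "measured", "known", "first", "only" and "open" are said of these compounds alone.

Compound 1, `CCS(=O)(=O)Nc1ccc2c(c1)C(NC(=S)Nc1ccc(C#N)cc1)CC(C)(C)O2`, and compound 3, `CCS(=O)(=O)Nc1ccc2c(c1)C(NC(=O)Nc1ccc(C#N)cc1)CC(C)(C)O2`, share a core that differs between them; that difference is not broken down here. In a functional assay on thoracic aorta (Rattus norvegicus) for inhibition (on this read-out higher numbers stand for an effect only at larger amounts of compound and lower numbers for an effect already at smaller amounts), compound 1 gives 12000 nM, and compound 3 gives 11800 nM. Compound 2, `CCS(=O)(=O)Nc1ccc2c(c1)C(NC(=S)Nc1cccc(Cl)c1)CC(C)(C)O2`, carries the change 3-chlorophenyl in place of 4-cyanophenyl on an amide-type nitrogen relative to compound 1; in this assay compound 2 gives 9800 nM, so that the step reads a 1.2-fold lower number from compound 1 to compound 2 (0.09 log units; within the scatter). Compound 4, `CCS(=O)(=O)Nc1ccc2c(c1)C(NC(=O)Nc1cccc(Cl)c1)CC(C)(C)O2`, carries the change 3-chlorophenyl in place of 4-cyanophenyl on an amide-type nitrogen relative to compound 3. This is the same kind of change, not the same: in compound 1 the amide-type nitrogen has a thiocarbonyl carbon as its other neighbour, in compound 3 a carbonyl carbon. Because a 1.2-fold lower number from compound 1 to compound 2 (0.09 log units; within the scatter) lies within the scatter, the step from compound 3 to compound 4 is expected to be similar, a 1.2-fold lower number from compound 3 to compound 4 (0.08 log units; within the scatter). Compound 4 is therefore estimated at 9800 nM, between 5000 nM and 19000 nM.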

Compound 4, half-maximal effective concentration: 17200 nM
Beside the measured number, compound 4's estimate is 1.8-fold (0.24 log units) below it; the range from low to high includes it.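

In this assay, the change on the core of compound 3 gives a 1.5-fold higher number from compound 3 to compound 4 (0.16 log units; within the scatter). Set beside the same change on the core of compound 1, the two steps cannot be told apart: the same change on two cores in this assay, a 1.2-fold lower number (0.09 log units; within the scatter) from compound 1 to compound 2 and a 1.5-fold higher number (0.16 log units; within the scatter) from compound 3 to compound 4, 1.8-fold (0.25 log units) apart, within the scatter of two such steps. This shows that, for these two pairs, swapping 4-cyanophenyl for 3-chlorophenyl has no effect beyond the scatter on either core, but it does not show that a real effect of the change would carry from one core to the other, as neither step offers one to follow.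

The compounds shown leave open what other groups on the amide-type nitrogen would do. An unsubstituted phenyl, a butyl chain or a carboxylic acid there might yet give steps large enough to compare between the two cores.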